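The compounds below may be only part of what the source reports. "The series", "measured", "known", "first", "only" and "open" are said of these compounds alone.

Measured so far:
compound 1, `CNC(=O)[C@H]1O[C@@H](n2cnc3c(N)nc(Cl)nc32)[C@H](O)[C@@H]1O`: 0.398 nM
compound 2, `CNc1nc(Cl)nc2c1ncn2[C@@H]1O[C@H](C(=O)NCCC(C)C)[C@@H](O)[C@H]1O`: 1.62 nM

In an assay on CHO cells for displacement of a labelled ligand from adenosine receptor A3 (Homo sapiens) (a higher number here means a weaker inhibitor, a lower number a stronger inhibitor), compound 1 gives 0.398 nM, the lower of the two numbers measured. Within the data shown here, the only other measured compound, compound 2, gives 1.62 nM in this assay, a higher number that lies beyond the usual scatter. Compound 2 differs from compound 1 in more than one place, so its value says nothing about any single change.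

Compound 3, `CNC(=O)[C@H]1O[C@@H](n2cnc3c(NCc4ccccc4C)nc(Cl)nc32)[C@H](O)[C@@H]1O`, is still unmeasured. It differs from compound 1 in one place: 2-methylbenzyl in place of hydrogen on a nitrogen on an aromatic ring. Among the measured compounds shown here, no measured pair isolates this change, so its effect is unknown, and the step from compound 1 to compound 3 could go in either direction. The step of a 1.5-fold higher number from compound 1 to compound 3 (0.18 log units; within the scatter) is expected to be modest, leaning slightly toward a higher number. Compound 3 is therefore estimated at 0.6 nM, within a range from 0.15 nM to 2.5 nM.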

Compound 3, inhibition constant: 2.19 nM
Estimate against measurement, compound 3: 3.7-fold (0.56 log units) below, within the range that was stated.
By their numbers in this assay, from the lowest: compound 1; then compounds 2 and 3 (each within the scatter of the next).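

Adding 2-methylbenzyl to the amino group of the core of compound 1 gives a 5.5-fold higher number from compound 1 to compound 3 (0.74 log units; beyond the scatter) in this assay, the first single-change reading at this nitrogen. Within this pair, the hydrogen gives the stronger binding, yet the added group, with its 8 heavy atoms, does not abolish it: compound 3 still gives 2.19 nM in this assay. Nothing available explains why the number rises with this change.

One pair cannot show whether the rise comes from the aromatic ring, from its methyl, or from the connecting carbon. As far as these compounds go, a plain benzyl group, a 3-methylbenzyl group or a simple ethyl chain on the same nitrogen would begin to separate these parts, and how far the position accepts such groups remains open.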